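The compounds below may be only part of what the source reports. "The series", "measured", "known", "first", "only" and "open" are said of these compounds alone.

Among the measured compounds shown here, in a functional assay on CNE-2 cells (Homo sapiens) for inhibition, read by MTT assay, with a stated time of 72 h (a higher number here means a weaker inhibitor, a lower number a stronger inhibitor), compound 2 (`Nc1ncnc2c1c(-c1cnc3[nH]ccc3c1)nn2CCCCCCCCC(=O)NO`) gives 2270 nM as the only true number so far. Compound 3 (`Nc1ncnc2c1c(-c1cnc3[nH]ccc3c1)nn2CCCCC(=O)NO`) shortens that chain (hydroxycarbamoyl in place of 4-(hydroxycarbamoyl)butyl on a saturated chain carbon, four bonds along the chain from an aromatic nitrogen), with hydroxycarbamoyl in place of 4-(hydroxycarbamoyl)butyl on a saturated chain carbon. Compound 1 (`Nc1ncnc2c1c(-c1cnc3[nH]ccc3c1)nn2CC(=O)NO`), with a chain shorter still, gives > 150000 nM which is a limit and not a number, and this points towards a weaker compound 3. Expected in this assay is a clear rise in the number, well beyond the usual scatter (a 6.6-fold higher number from compound 2 to compound 3 (0.82 log units; beyond the scatter)). For compound 3 the estimated value is 15000 nM (expected range 4000 nM to 60000 nM).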

Compound 3, half-maximal inhibitory concentration: > 150000 nM
Compound 3: a limit, no number (the forecaster's own chance of this, stated with the estimate: 15%); middle value at least 10-fold (1.00 log units) from the limit.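

In this assay, the length of this chain proves decisive even at the intermediate length, not only at the very short chain of compound 1, with hydroxycarbamoyl in place of 4-(hydroxycarbamoyl)butyl giving a large loss (an at least 66-fold higher number from compound 2 to compound 3 (1.82 log units; beyond the scatter)). Compound 3 gives > 150000 nM as a limit and not a number, so the true loss may be greater. The step between the two short-chain compounds cannot be read, since both stop at the same limit: the limit of > 150000 nM in this assay, at which 2 of the 3 values shown sit.

Going by these compounds, whether a longer chain than that of compound 2 would lower the number further stays open. So does whether a carboxylic acid could replace the hydroxycarbamoyl end of that chain.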